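This account rests on a few compounds, and the source may have more. Where it says the series, first, only, none or still open, it means among the compounds named here.

Three compounds share one core and differ only in the group carried on an aromatic nitrogen. In an assay on Prostate gland for inhibition of steroid 5-alpha-reductase (Rattus norvegicus) (a lower number here means a stronger inhibitor, a higher number a weaker inhibitor), compound 1 `CCCCC(CC)n1ccc2cc(/C(C)=C/C(=O)Nc3ccccc3OCCCC(=O)O)ccc21` gives 7.1 nM. Compound 2 `C/C(=C\C(=O)Nc1ccccc1OCCCC(=O)O)c1ccc2c(ccn2Cc2ccccc2C)c1` gives 69 nM, and compound 3 `C/C(=C\C(=O)Nc1ccccc1OCCCC(=O)O)c1ccc2c(ccn2Cc2ccc(C(F)(F)F)cc2)c1` gives 300 nM, the highest of the three numbers, so compound 3 is the weakest inhibitor among them. The step from compound 3 to compound 4 `C/C(=C\C(=O)Nc1ccccc1OCCCC(=O)O)c1ccc2c(ccn2C(CC(C)C)c2ccccc2)c1` is this change: 3-methyl-1-phenylbutyl in place of 4-(trifluoromethyl)benzyl on an aromatic nitrogen. Among the measured compounds shown here, two measured steps bear on it. a 42-fold higher number from compound 1 to compound 3 (1.63 log units; beyond the scatter) shows that the 4-(trifluoromethyl)benzyl group on this nitrogen gives a much weaker inhibitor than the 1-ethylpentyl chain. a 4.3-fold higher number from compound 2 to compound 3 (0.64 log units; beyond the scatter) shows that a phenyl ring bearing trifluoromethyl does worse than one bearing methyl. The entering 3-methyl-1-phenylbutyl group joins a chain resembling that of compound 1 with a phenyl ring free of trifluoromethyl, so a large fall in the number is expected for compound 4, though not necessarily all the way to compound 1. Compound 4 is expected to give 20 nM, within 5 nM to 80 nM. This estimate corresponds to an expected step of a 15-fold lower number from compound 3 to compound 4 (1.18 log units; beyond the scatter).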

Compound 4, half-maximal inhibitory concentration: 6.3 nM
Compound 4: the middle estimate sits 3.2-fold (0.50 log units) above what was measured; measured number inside the range.
By their numbers in this assay, from the lowest: compounds 4 and 1 (each within the scatter of the next); then compound 2; then compound 3.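

Replacing 4-(trifluoromethyl)benzyl with 3-methyl-1-phenylbutyl keeps the count of 11 heavy atoms and one aromatic ring, yet it gives a 48-fold lower number from compound 3 to compound 4 (1.68 log units; beyond the scatter), and replacing 2-methylbenzyl with the same group gives an 11-fold lower number from compound 2 to compound 4 (1.04 log units; beyond the scatter), so a phenyl ring in the group on this nitrogen does not by itself go with a weak inhibitor. The comparison with the all-chain group gives a 1.1-fold lower number from compound 1 to compound 4 (0.05 log units; within the scatter), which places 3-methyl-1-phenylbutyl level with 1-ethylpentyl, and among these four compounds the two lowest numbers belong to the groups whose carbon bound to the aromatic nitrogen carries two further carbon branches, while the two benzyl groups do not have that branching. No measurement available here explains these differences.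

From the compounds shown here alone, whether a cyclohexyl ring could stand in for the phenyl ring of compound 4 remains open. So does the effect of a longer chain in place of its 3-methylpropyl-type branch, or of an amine on its phenyl ring.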